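Carbamate for urea at the piperidine nitrogen of compound 1

The source may hold more compounds than are shown below. What is called first, only, known or untested is meant among the compounds shown, and "the series" means these compounds.

Compound 1 `CC(C)NC(=O)N1CCC(CN(C2Cc3cc(C#N)ccc3N(Cc3cncn3C)C2)S(=O)(=O)c2ccccn2)CC1`: 0.6 10^-6 cm/s
Compound 2 `Cn1cncc1CN1CC(N(Cc2cccc(-n3cccc3)c2)S(=O)(=O)c2ccccn2)Cc2cc(C#N)ccc21`: 2.3 10^-6 cm/s
Compound 3 `Cn1cncc1CN1CC(N(CC2CCN(C(=O)NC(C)(C)C)CC2)S(=O)(=O)c2ccccn2)Cc2cc(C#N)ccc21`: 0.6 10^-6 cm/s

In an ADME assay on Caco-2 cells (Homo sapiens) for permeability, in the apical to basolateral direction (a higher number here means that the compound crosses the layer faster, a lower number that the compound crosses the layer more slowly), compound 1 stands level with compound 3, the two together giving the lowest numbers of the three, while the step of a 3.8-fold higher number from compound 1 to compound 2 (0.58 log units; beyond the scatter) is modest. Compound 4 `CCOC(=O)N1CCC(CN(C2Cc3cc(C#N)ccc3N(Cc3cncn3C)C2)S(=O)(=O)c2ccccn2)CC1` differs from compound 1 by ethoxy in place of isopropylamino on a carbonyl carbon. For the measured compounds named here, no measured step touches the carbonyl carbon itself; the nearest, no change at the digits printed from compound 1 to compound 3 (within the scatter), alters the same isopropylcarbamoyl group and changes nothing, whereas replacing the whole 1-(isopropylcarbamoyl)piperidin-4-yl in a 3.8-fold higher number from compound 1 to compound 2 (0.58 log units; beyond the scatter) raises the number. A small rise, near the scatter, is therefore expected: a 2.0-fold higher number from compound 1 to compound 4 (0.30 log units; within the scatter). Compound 4 is estimated at 1.2 10^-6 cm/s, within 0.5 10^-6 cm/s to 3 10^-6 cm/s.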

Compound 4, apparent permeability: 2.6 10^-6 cm/s
Estimate against measurement, compound 4: 2.2-fold (0.34 log units) below, within the range that was stated.
By their numbers in this assay, from the lowest: compounds 1 and 3 (each within the scatter of the next); then compounds 2 and 4 (each within the scatter of the next).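

In this assay, ethoxy on the carbonyl carbon, which takes away the hydrogen-bond donor of isopropylamino, gives a 4.3-fold higher number from compound 1 to compound 4 (0.64 log units; beyond the scatter), so this position responds to the change. Replacing (tert-butyl)amino with ethoxy gives the same size of step, a 4.3-fold higher number from compound 3 to compound 4 (0.64 log units; beyond the scatter), so both ureas stand apart from the carbamate. With a 1.1-fold higher number from compound 2 to compound 4 (0.05 log units; within the scatter), 3-(1H-pyrrol-1-yl)phenyl is not needed to reach that level. No evidence here gives a cause for these steps. On these data alone, whether dimethylamino or methoxy on the same carbonyl carbon would behave like ethoxy stays open.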